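The source may report more compounds than this note shows. Statements on the series, on what has been measured and on what is new or still open speak of the compounds shown alone.

Measured so far in a functional assay on HT-29 cells (Homo sapiens) for cytotoxicity, read by MTT assay, with a stated time of 48 h; on this read-out higher numbers stand for weaker inhibition and lower numbers for stronger inhibition:
compound 1 `O=C(/C=C(/C=C/c1ccc(O)cc1)NCCCO)/C=C/c1ccc(O)cc1`, 58900 nM
compound 2 `COc1cc(/C=C/C(=O)/C=C(/C=C/c2ccc(O)c(OC)c2)NCCCO)ccc1O`, a limit of the assay, > 100000 nM
compound 3 `COCCNC(=C\C(=O)/C=C/c1ccc(O)cc1)/C=C/c1ccc(O)cc1`, 57400 nM

In this assay compound 1 gives 58900 nM and compound 3 gives 57400 nM. The change between them is methoxy in place of hydroxymethyl on a saturated chain carbon, two bonds along the chain from an amine nitrogen, and it produced a 1.0-fold lower number from compound 1 to compound 3 (0.01 log units; within the scatter). How the core of compound 2 differs from that of compound 1 is not broken down here. Compound 4 `COCCNC(=C\C(=O)/C=C/c1ccc(O)c(OC)c1)/C=C/c1ccc(O)c(OC)c1` is not yet measured; it arises from compound 2 by the same change, (methoxy in place of hydroxymethyl on a saturated chain carbon, two bonds along the chain from an amine nitrogen). Because the measured step was a 1.0-fold lower number from compound 1 to compound 3 (0.01 log units; within the scatter), the step from compound 2 to compound 4 is expected to be a step that the limit leaves unreadable from compound 2 to compound 4 in this assay. Since compound 2 sits at the limit of > 100000 nM in this assay, at which 1 of the 3 values shown sits, compound 4 is expected to return a limit as well. Compound 4 is estimated at 120000 nM, between 60000 nM and 250000 nM.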

Compound 4, half-maximal inhibitory concentration: > 100000 nM
Compound 4 ended at the assay's limit; the forecaster's own chance of this, stated with the estimate: 70%; the middle value is on the limit's open side.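

Compound 2 and compound 4 both end at a limit in this assay, and no step can be read between them: the limit of > 100000 nM in this assay, at which 2 of the 4 values shown sit.

The compounds shown leave open whether methoxy in place of hydroxymethyl changes the number at all on the core of compound 2.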